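A few compounds are considered here, and "the series" means these few. Any claim that something is new, unique, unknown or untested is made for them only; others in the source may bear on it.

Measured so far:
compound 1, `Nc1nc(N/N=C/c2ccc(-c3ccccc3)cc2)nc2c1ncn2[C@@H]1O[C@H](CO)[C@@H](O)[C@H]1O`: 7860 nM
compound 2, `Nc1nc(N/N=C/c2ccc[nH]2)nc2c1ncn2[C@@H]1O[C@H](CO)[C@@H](O)[C@H]1O`: 8 nM

In an assay on CHO-K1 cells for displacement of a labelled ligand from adenosine receptor A1 (Homo sapiens), read by scintillation counting, with a stated time of 60 min (a lower number here means a stronger inhibitor, a higher number a weaker inhibitor), compound 2 gives 8 nM, the lowest of the two numbers; compound 1 gives 7860 nM, a gap far beyond the scatter. Compound 3, `Nc1nc(N/N=C/c2ccc(C(F)(F)F)cc2)nc2c1ncn2[C@@H]1O[C@H](CO)[C@@H](O)[C@H]1O`, differs from compound 2 by 4-(trifluoromethyl)phenyl in place of 1H-pyrrol-2-yl on a carbon with a double bond to nitrogen. For the measured compounds named here, no measured pair isolates this change, but compound 3 carries a six-membered carbon ring as compound 1 does, and compound 1 gives 7860 nM. A large step toward weaker binding is therefore expected, a 250-fold higher number from compound 2 to compound 3 (2.40 log units; beyond the scatter). For compound 3 the expected value in this assay is 2000 nM, estimated to lie between 300 nM and 15000 nM.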

Compound 3, inhibition constant: 37 nM
Beside the measured number, compound 3's estimate is 54-fold (1.73 log units) above it; the whole stated range lies above it.
By their numbers in this assay, from the lowest: compound 2; then compound 3; then compound 1.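

In this assay, a six-membered carbon ring on the carbon with a double bond to nitrogen is compatible with strong binding: 4-(trifluoromethyl)phenyl in place of 1H-pyrrol-2-yl gives only a 4.6-fold higher number from compound 2 to compound 3 (0.67 log units; beyond the scatter). The weak binding of compound 1 therefore does not follow from the six-membered ring alone, as trifluoromethyl in place of phenyl on an aromatic carbon gives a 210-fold lower number from compound 1 to compound 3 (2.33 log units; beyond the scatter). No supporting data explain either step.

Still open, from the compounds shown here alone, is how a methyl, an amine or a carboxylic acid on that aromatic carbon would compare with trifluoromethyl and phenyl. Also open, going by these compounds, is how an unsubstituted phenyl would compare with both substituted rings.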